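The compounds below may be only part of what the source reports. "The series", "measured", "known", "first", "only" and "open" are said of these compounds alone.

Compound 1 `COc1cccc(/C=C/C(=O)c2ccc(OC)c3c2OC(C)(C)C=C3)c1` gives > 10000 nM in a functional assay on HT-29 cells (Homo sapiens) for antiproliferative activity, read by MTT assay, with a stated time of 24 h (on this read-out higher numbers stand for weaker inhibition and lower numbers for stronger inhibition), which is a limit of the assay. Compound 2 `COc1ccc(C(=O)/C=C/c2cc(OC)c(OC)c(OC)c2)c2c1C=CC(C)(C)O2` gives > 10000 nM, also a limit. Compound 3 `COc1ccc(C(=O)/C=C/c2ccc(N(c3ccccc3)c3ccccc3)cc2)c2c1C=CC(C)(C)O2` gives > 10000 nM, again a limit.

Compound 1 therefore stands at a limit rather than at a number, and the two other compounds stand there too: the limit of > 10000 nM in this assay, at which 3 of the 3 values shown sit. Among the compounds with values here, no step between measured compounds can be read from such values. Compound 4 `COc1ccc(C(=O)/C=C/c2cccc([N+](=O)[O-])c2)c2c1C=CC(C)(C)O2` differs from compound 1 in one place: nitro in place of methoxy on an aromatic carbon. Within the data shown here, the three measured values give no step to lean on. The expected step from compound 1 to compound 4 is a step that the limit leaves unreadable from compound 1 to compound 4, meaning no change beyond the scatter is expected. Compound 4 is estimated to give 15000 nM, with a range from 3000 nM to 60000 nM, and will most likely again be reported only as a limit.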

Compound 4, half-maximal inhibitory concentration: 4260 nM
Compound 4: the middle estimate sits 3.5-fold (0.55 log units) above what was measured; measured number inside the range.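

In this assay the change from 3-methoxyphenyl to 3-nitrophenyl brings an at least 2.3-fold lower number from compound 1 to compound 4 (0.37 log units; beyond the scatter) and so shows that this aromatic carbon responds to the group it carries. Compound 4 is the only compound here to give a number rather than a limit, and the steps among the other compounds cannot be read: the limit of > 10000 nM in this assay, at which 3 of the 4 values shown sit.

From the compounds shown here alone, the full size of the step stays open, for its starting point is only a limit. Going by these compounds, whether an amine or a carboxylic acid on this same aromatic carbon would lower the number further also stays open.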